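Isobutyl to pentyl on the shared core

The source may hold more compounds than are shown below. What is called first, only, known or untested is meant among the compounds shown, and "the series" means these compounds.

In a functional assay on MDA-MB-468 cells (Homo sapiens) for antiproliferative activity, read by MTT assay, with a stated time of 72 h (a higher number here means a weaker inhibitor, a lower number a stronger inhibitor), compound 3 `COc1cc(-c2nccn2CC(C)C)cc(OC)c1OC` gives > 100000 nM, which is a limit and not a number. Compound 1 `CCn1ccnc1-c1cc(OC)c(OC)c(OC)c1` gives > 100000 nM, also a limit. Among the compounds with values here, compound 2 `CCCCn1ccnc1-c1cc(OC)c(OC)c(OC)c1` gives 44100 nM, the only true number among the three.

Compound 4 `CCCCCn1ccnc1-c1cc(OC)c(OC)c(OC)c1` differs from compound 3 by butyl in place of isopropyl on a saturated chain carbon bound to an aromatic nitrogen. Cut one bond further out, the same difference reads isobutyl to pentyl.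

Within the data shown here, two measured steps bear on this change. The first, an at least 2.2-fold lower number from compound 1 to compound 2 (0.35 log units; beyond the scatter), comes with ethyl in place of hydrogen on the chain. The second, an at least 2.2-fold higher number from compound 2 to compound 3 (0.35 log units; beyond the scatter), comes with isopropyl in place of propyl and is the closer guide, since the change to compound 4 removes the same branching. Both steps are open-ended, so neither fixes a size.

In this assay, a move to a lower number is therefore expected, beyond the scatter but modest, with compound 2 as the nearest reference at 44100 nM. The expected change is an at least 3.3-fold lower number from compound 3 to compound 4 (0.52 log units; beyond the scatter). Another limit remains possible, given (the limit of > 100000 nM in this assay, at which 2 of the 3 values shown sit). For compound 4 the estimate is 30000 nM, with an expected range of 10000 nM to 100000 nM.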

Compound 4, half-maximal inhibitory concentration: 57900 nM
Compound 4: middle estimate off by 1.9-fold (0.29 log units), on the low side, within the range that was stated.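

In this assay, methyl in place of hydrogen, four bonds along the chain from the aromatic nitrogen, gives a 1.3-fold higher number from compound 2 to compound 4 (0.12 log units; within the scatter), so the pentyl and butyl chains read as level and a second true number now stands in this series. The steps from the two compounds held at a limit are less firm: butyl in place of isopropyl gives an at least 1.7-fold lower number from compound 3 to compound 4 (0.23 log units; that floor lies within the scatter), and propyl in place of hydrogen gives an at least 1.7-fold lower number from compound 1 to compound 4 (0.23 log units; that floor lies within the scatter), so neither floor alone shows a change at this position. Both steps start from a limit and not from a number, which leaves their true size unknown: the limit of > 100000 nM in this assay, at which 2 of the 4 values shown sit.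

Still open, as far as these compounds go, is whether a longer chain, such as hexyl or octyl, stays level with the pentyl and butyl chains or moves away from them in this assay. Also open, from the compounds shown here alone, is how an amine or a carboxylic acid carried on the chain would read against these simple alkyl groups on the shared core.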